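Alkynyl substituents on a cytosine nucleoside core: cytotoxicity

This account rests on a few compounds, and the source may have more. Where it says the series, first, only, none or still open, it means among the compounds named here.

Measured compounds:
compound 1, `CCCC#Cc1cn([C@@H]2O[C@H](CO)[C@@H](O)[C@H](O)[C@H]2O)c(=O)nc1N`, >= 250000 nM
compound 2, `CC(C)(C)c1ccc(C#Cc2cn([C@@H]3O[C@H](CO)[C@@H](O)[C@H](O)[C@H]3O)c(=O)nc2N)cc1`, > 250000 nM

In a functional assay on L1210 cells (Mus musculus) for cytotoxicity, with a stated time of 48 h (on this read-out higher numbers stand for weaker inhibition and lower numbers for stronger inhibition), compound 1 gives >= 250000 nM, which is a limit of the assay rather than a number. In this assay compound 2 gives > 250000 nM, again a limit and not a number. Among the measured compounds shown here, compound 2 therefore stands at a limit, and the only measured step, a step that the two limits leave unreadable from compound 1 to compound 2, cannot be read; the evidence is the limit of > 250000 nM in this assay, at which 1 of the 2 values shown sits, and (the limit of >= 250000 nM in this assay, at which 1 of the 2 values shown sits).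

Compound 3, `C#Cc1cn([C@@H]2O[C@H](CO)[C@@H](O)[C@H](O)[C@H]2O)c(=O)nc1N`, differs from compound 2 by hydrogen in place of 4-(tert-butyl)phenyl on a triple-bonded carbon. For the measured compounds named here, the one measured step concerns a change at the same triple-bonded carbon, but since both of its ends are limits it gives no size and no direction. Nothing measured here therefore supports an expectation of a step beyond the scatter in this assay, and compound 3 is most likely to come back at a limit as well. The estimate for compound 3 is 250000 nM, with a range from 50000 nM to 600000 nM, and the expected step is a number no higher from compound 2 to compound 3 (the limit leaves the size open).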

Compound 3, half-maximal inhibitory concentration: >= 250000 nM
Compound 3: no number, only a limit (the forecaster's own chance of this, stated with the estimate: 70%); the middle value lies on the limit itself.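

Compound 3 also sits at a limit of the assay, so no step linking it to compound 1 or compound 2 can be read in this assay: the limit of >= 250000 nM in this assay, at which 2 of the 3 values shown sit.

The compounds shown leave open how propyl, 4-(tert-butyl)phenyl and hydrogen on the triple-bonded carbon rank against one another, and whether any group there gives a value that is a number rather than a limit.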